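The source may hold more compounds than are shown below. What is called first, only, known or untested is meant among the compounds shown, and "the series" means these compounds.

Compounds measured so far in a functional assay on HT cells (Homo sapiens) for antiproliferative activity, read by fluorescence, with a stated time of 72 h; a higher number here means a weaker inhibitor of growth, a lower number a stronger inhibitor of growth

Compound 1 (`CC(C)c1n[nH]c2c(NCc3ccc(-c4ccccn4)cc3)nc(SCCO)nc12`) gives 48 nM
Compound 2 (`CC(C)c1n[nH]c2c(NCc3ccc(-c4ccccn4)cc3)nc(SCC3CNC(=O)O3)nc12`) gives 80 nM
Compound 3 (`CC(C)c1n[nH]c2c(NCc3ccc(-c4ccccn4)cc3)nc(SCCC(N)=O)nc12`) gives 120 nM

Compound 3 stands apart from only one of the other two. The gap to the hydroxy compound (a 2.5-fold higher number from compound 1 to compound 3 (0.40 log units; beyond the scatter)) is modest, while the gap to the oxazolidinone compound (a 1.5-fold higher number from compound 2 to compound 3 (0.18 log units; within the scatter)) is no real difference.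

Compound 4 (`CNCCSc1nc(NCc2ccc(-c3ccccn3)cc2)c2[nH]nc(C(C)C)c2n1`) carries methylamino in place of carbamoyl on a saturated chain carbon, two bonds along the chain from a sulfur. The closest evidence is the change at that same place, where carbamoyl replaced hydroxy (a 2.5-fold higher number from compound 1 to compound 3 (0.40 log units; beyond the scatter)). The change of 2-oxo-1,3-oxazolidin-5-yl for hydroxymethyl (a 1.7-fold higher number from compound 1 to compound 2 (0.22 log units; within the scatter)) also stayed small. Going by the values given here, no measured compound carries methylamino, so these steps bound only the likely size. No step beyond the scatter is expected in this assay, with a slight lean towards a lower number, as removing carbamoyl might move the value back towards that of compound 1 (48 nM). The expected change is small (a 1.6-fold lower number from compound 3 to compound 4 (0.20 log units; within the scatter)). Compound 4 is expected at 75 nM (estimated range 28 nM to 200 nM).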

Compound 4, concentration for 50% growth inhibition: 56 nM
Estimate against measurement, compound 4: 1.3-fold (0.13 log units) above; the range from low to high includes it.
By their numbers in this assay, from the lowest: compounds 1, 4, 2 and 3 (each within the scatter of the next, the first and the last beyond it).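

In this assay, methylamino in place of carbamoyl on the saturated chain carbon gives a 2.1-fold lower number from compound 3 to compound 4 (0.33 log units; beyond the scatter), a modest step that is as large as the one separating carbamoyl from hydroxy. Methylamino cannot be told apart from hydroxy, with a 1.2-fold higher number from compound 1 to compound 4 (0.07 log units; within the scatter), or from the larger oxazolidinone group, with a 1.4-fold lower number from compound 2 to compound 4 (0.15 log units; within the scatter), so three quite different groups at this position now give matching values, and only carbamoyl lies beyond the scatter of any other group, without doing so against the oxazolidinone. No supporting measurement accounts for the carbamoyl step.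

The compounds shown leave open whether a primary amine, dimethylamino or a carboxylic acid at this place would match methylamino. They also leave open whether a longer chain between the sulfur and the amine would keep the value of compound 4.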